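The source may report more compounds than this note shows. Statements on the series, on what has been measured and on what is new or still open speak of the compounds shown alone.

Measured in a functional assay on MV4-11 cells (Homo sapiens) for antiproliferative activity, read by CCK-8 assay, with a stated time of 72 h; a higher number here means a weaker inhibitor, a lower number a stronger inhibitor:
- compound 1 `CC(C)Oc1ccc(C(C)(C)O)cc1-c1cn(C)c(=O)c2[nH]c(C(=O)NCCCCCCC(=O)NO)cc12`: 160 nM
- compound 2 `Cn1cc(-c2ccccc2Oc2ccccc2)c2cc(C(=O)NCCCC(=O)NO)[nH]c2c1=O`: 380 nM
- compound 3 `Cn1cc(-c2ccccc2Oc2ccccc2)c2cc(C(=O)NCc3ccc(C(=O)Nc4ccccc4N)cc3)[nH]c2c1=O`: 80 nM

Compound 3 has the lowest number of the three, but its lead over compound 1 does not hold up, as the two values lie within the usual scatter of each other. Only compound 2 stands clearly apart from compound 3, with a higher number and so weaker inhibition.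

The next compound, compound 4 `Cn1cc(-c2ccccc2F)c2cc(C(=O)NCc3ccc(C(=O)Nc4ccccc4N)cc3)[nH]c2c1=O`, keeps the rest of compound 3 but carries fluoro in place of phenoxy on an aromatic carbon, on a six-membered aromatic ring of carbon only, ortho to a large group: fluoro in place of phenoxy on an aromatic carbon.

Among the compounds with values here, no measured pair isolates this change, so the evidence is indirect. Compound 1 carries no phenoxy and reads 160 nM, yet it also differs from compound 3 elsewhere. That value argues against expecting a collapse in this assay, though the replacement removes a whole ring. A moderate loss is therefore expected, with a higher number that may only just clear the scatter.

The estimated change is a 3.1-fold higher number from compound 3 to compound 4 (0.49 log units; beyond the scatter).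

Compound 4 is expected to read about 250 nM, within an estimated range of 90 nM to 800 nM.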

Compound 4, half-maximal inhibitory concentration: 230 nM
Estimate against measurement, compound 4: 1.1-fold (0.04 log units) above; the range from low to high includes it.
By their numbers in this assay, from the lowest: compounds 3, 1, 4 and 2 (each within the scatter of the next, the first and the last beyond it).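

In this assay, within the data shown here, fluoro in place of phenoxy on an aromatic carbon, ortho to a large group, gives a 2.9-fold higher number from compound 3 to compound 4 (0.46 log units; beyond the scatter), and this is the first reading of this position in which nothing else in the molecule differs. The step is modest yet beyond the scatter, so phenoxy, with its six-membered aromatic ring of carbon only, counts for something here, though compound 4 still gives 230 nM without that ring. Nothing in the data shown says why the number rises with this change.

As far as these compounds go, with only phenoxy and fluoro compared at this position, it remains open whether the ring or its oxygen matters more: methoxy would keep the oxygen without the ring, while phenyl would keep the ring without the oxygen. From the compounds shown here alone, it also remains open whether the same replacement would cost as much on the shorter hydroxamic acid chain of compound 2, where phenoxy is present, as it does on the side chain shared by compound 3 and compound 4.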